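The source may report more compounds than this note shows. Statements on the series, on what has been measured and on what is new or still open speak of the compounds shown alone.

The measured compounds and their numbers in a functional assay on J774 cells (Mus musculus) for cytotoxicity, read by resazurin assay, with a stated time of 72 h; a higher number here means a weaker inhibitor, a lower number a stronger inhibitor:
compound 1 `O=S(=O)(Nc1cccc(CO)c1)c1ccc(-c2ccccc2)cc1` gives 2200 nM;
compound 2 `O=S(=O)(Nc1ccc(CO)c(CO)c1)c1ccc(-c2ccc(F)cc2F)cc1` gives 150 nM;
compound 3 `O=S(=O)(Nc1cccc(CO)c1)c1ccc(-c2ccc(C(F)(F)F)cc2)cc1` gives 2500 nM.

Compound 1 stands second highest of the three numbers. Its nearest neighbour is compound 3, and the step of a 1.1-fold higher number from compound 1 to compound 3 (0.06 log units; within the scatter) lies within the scatter. Compound 2 is the furthest, with a number well beyond the scatter below that of compound 1, but it differs from compound 1 in more than one place, so the two values show only the spread reached in this series.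

Compound 4 `O=S(=O)(Nc1cccc(CO)c1)c1ccc(-c2ccccc2F)cc1` has not yet been measured. It differs from compound 1 by fluoro in place of hydrogen on an aromatic carbon. Within the data shown here, the only single-place step measured, a 1.1-fold higher number from compound 1 to compound 3 (0.06 log units; within the scatter), also changed the same ring at an aromatic carbon and stayed within the scatter. Among the measured compounds shown here, no step records fluoro alone; compound 2 carries fluoro among other changes, and its lower number cannot be cut apart. Compound 4 is therefore expected to sit near compound 1, with at most a modest lowering: a 1.2-fold lower number from compound 1 to compound 4 (0.09 log units; within the scatter). The estimate for compound 4 in this assay is 1800 nM, ranging from 700 nM to 4500 nM.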

Compound 4, half-maximal inhibitory concentration in the J774 assay: 1300 nM
Compound 4: middle estimate off by 1.4-fold (0.14 log units), on the high side; measured number inside the range.
By their numbers in the J774 assay, from the lowest: compound 2; then compounds 4, 1 and 3 (each within the scatter of the next).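

Phenyl to 2-fluorophenyl gives the only reading of fluoro alone in the J774 assay, and at this place, ortho to a large group, it amounts to a 1.7-fold lower number from compound 1 to compound 4 (0.23 log units; within the scatter). Like the trifluoromethyl step, a 1.1-fold higher number from compound 1 to compound 3 (0.06 log units; within the scatter), it therefore leaves the number within the scatter, so neither single change on this ring shifts cytotoxicity measurably. The same fluoro does show a clear effect on another property, which the earlier compounds could not reveal, with solubility rising in a physicochemical assay for solubility, read by HPLC, in simulated intestinal fluid, measured as thermodynamic solubility, with a stated time of 24 h (a lower number here means a less soluble compound, a higher number a more soluble compound), from compound 1 at 11 ug/mL to compound 4 at 57 ug/mL: the measured solubility of compound 1, 11 ug/mL, and of compound 4, 57 ug/mL, a 5.2-fold higher number (0.71 log units; beyond the scatter)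

The compounds shown leave open whether this gain in solubility belongs to fluoro at this place alone or would also come with chloro or methoxy here. They also leave open whether an amine on the same carbon would keep the number in the J774 assay where it stands.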